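The compounds below may be only part of what the source reports. "The series", "measured", "known", "first", "only" and "open" are said of these compounds alone.

Compound 1 `CCOCCOC(=O)Nc1cc2nc(C3CCCCC3)[nH]c2cc1N(C)C` gives > 100 ug/mL in an ADME assay on Vero cells (Chlorocebus sabaeus) for cytotoxicity, read by resazurin assay, with a stated time of 3 days (a higher number here means a weaker inhibitor, a lower number a stronger inhibitor), which is a limit.
Compound 2 `CCCOCC(=O)Nc1cc2nc(C3CCCCC3)[nH]c2cc1N(C)C` gives < 50 ug/mL in this assay , also a limit.

Compound 2 thus stands at the lower of the two numbers shown, though only as a limit. Among the compounds with values here, the one measured step, an at least 2.0-fold lower number from compound 1 to compound 2 (0.30 log units; that floor lies within the scatter), swapped propoxymethyl in place of 2-ethoxyethoxy on a carbonyl carbon, and its true size is unknown because its ends sit at the limit of > 100 ug/mL in this assay, at which 1 of the 2 values shown sits, and (the limit of < 50 ug/mL in this assay, at which 1 of the 2 values shown sits). Compound 3 `CN(C)c1cc2[nH]c(C3CCCCC3)nc2cc1NC(=O)c1ccco1` is not yet measured in this assay ; it differs from compound 2 by furan-2-yl in place of propoxymethyl on a carbonyl carbon. Within the data shown here, no measured step covers this swap: the single step known concerns a different group at the same carbonyl carbon and gives no direction for furan-2-yl. Compound 3 is therefore expected to stay close to compound 2, with a step that the limit leaves unreadable from compound 2 to compound 3. The estimate for compound 3 is 30 ug/mL, spanning 10 ug/mL to 100 ug/mL.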

Compound 3, half-maximal inhibitory concentration: > 100 ug/mL
Compound 3 ended at the assay's limit; the forecaster's own chance of this, stated with the estimate: 40%; middle value at least 3.3-fold (0.52 log units) from the limit.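

With furan-2-yl in place of propoxymethyl on the carbonyl carbon, the change gives an at least 2.0-fold higher number from compound 2 to compound 3 (0.30 log units; that floor lies within the scatter) in this assay, although the two groups match in heavy atoms and in hydrogen-bond donors and acceptors and differ in the five-membered aromatic ring of furan-2-yl. Compound 3 gives > 100 ug/mL, which is a limit. A ring on this carbonyl carbon thus sits at the same limit as the 2-ethoxyethoxy group of compound 1, propoxymethyl alone stands at the limit on the low side, and the step from compound 1 to compound 3 cannot be read.

As far as these compounds go, the true size of the step to compound 3 stays unknown because its upper end is a limit: the limit of > 100 ug/mL in this assay, at which 2 of the 3 values shown sit. Whether a saturated ring such as tetrahydrofuran-2-yl or a shorter chain such as methoxymethyl would follow furan-2-yl or propoxymethyl on this carbonyl carbon remains open.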